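Adding 4-methylpiperazin-1-yl to compound 2

This account rests on a few compounds, and the source may have more. Where it says the series, first, only, none or still open, it means among the compounds named here.

Compound 1 `Cc1ccccc1Nc1nc(NCc2ccccc2)ncc1Cl`: > 100000 nM
Compound 2 `Cc1ccccc1Nc1nc(Nc2ccccn2)ncc1Cl`: 20100 nM

Among the compounds with values here, in a functional assay on Jurkat cells (Homo sapiens) for inhibition, read by CCK-8 assay, with a stated time of 48 h (on this read-out higher numbers stand for weaker inhibition of growth and lower numbers for stronger inhibition of growth), compound 2 gives 20100 nM, the only true number so far. The entry for compound 1, > 100000 nM, is a limit of the assay.

Compound 3 `Cc1ccccc1Nc1nc(Nc2ccc(N3CCN(C)CC3)cn2)ncc1Cl` keeps all of compound 2 and changes one place on its pyridin-2-yl group: 4-methylpiperazin-1-yl in place of hydrogen on an aromatic carbon. Within the data shown here, no measured step tests this change directly. Among the measured compounds shown here, the nearest guide is the single step measured so far, an at least 4.9-fold lower number from compound 1 to compound 2 (0.69 log units; beyond the scatter), which concerns the same substituent but starts from a limit, so it gives a direction only loosely. On that thin basis, a further move towards stronger inhibition of growth is expected, with an estimated size of a 6.7-fold lower number from compound 2 to compound 3 (0.83 log units; beyond the scatter). For compound 3 the expected value is 3000 nM, with an estimated range from 500 nM to 15000 nM.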

Compound 3, concentration for 50% growth inhibition: 8080 nM
Estimate against measurement, compound 3: 2.7-fold (0.43 log units) below; the measured number falls inside the stated range.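

In this assay, 4-methylpiperazin-1-yl on an aromatic carbon of the pyridin-2-yl group, two atoms from the ring nitrogen, gives a 2.5-fold lower number from compound 2 to compound 3 (0.40 log units; beyond the scatter). This position therefore accepts a group much larger than hydrogen, and growth inhibition gets modestly stronger rather than being lost. It is also the first step here with a true number at both ends and the first change on the pyridin-2-yl group itself, whereas the earlier comparison changed the group on the nitrogen and started from a limit: the limit of > 100000 nM in this assay, at which 1 of the 3 values shown sits.

The compounds shown do not separate the part played by the piperazine ring from that of its methyl group, which morpholin-4-yl or unsubstituted piperazin-1-yl could address. On these data alone, how 4-methylpiperazin-1-yl would behave on another carbon of the pyridin-2-yl group also remains open.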